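The source may report more compounds than this note shows. Statements on the series, on what has been measured and on what is new or still open speak of the compounds shown alone.

Compound 1 `CC(C)c1ccc(-c2nc3sccn3c2/C=N/OCc2ccc(Cl)c(Cl)c2)cc1` gives 590 nM in an assay on HepG2 cells for agonist activity at nuclear receptor subfamily 1 group I member 3 (Homo sapiens), read by a luciferase reporter, with a stated time of 23 h; on this read-out lower numbers stand for an effect already at smaller amounts and higher numbers for an effect only at larger amounts of compound.
Compound 2 `Clc1ccc(CO/N=C/c2c(-c3cccc4ccccc34)nc3sccn23)cc1Cl` gives 940 nM in this assay.
Compound 3 `CCc1nc2sccn2c1/C=N/OCc1ccc(Cl)c(Cl)c1` gives 2600 nM in this assay.

Compound 3 stands at the highest number of the three: the step of a 4.4-fold higher number from compound 1 to compound 3 (0.64 log units; beyond the scatter) and the step of a 2.8-fold higher number from compound 2 to compound 3 (0.44 log units; beyond the scatter) both reach beyond the scatter, while the step of a 1.6-fold higher number from compound 1 to compound 2 (0.20 log units; within the scatter) does not. Compound 4 `Fc1ccc(-c2nc3sccn3c2/C=N/OCc2ccc(Cl)c(Cl)c2)cc1` differs from compound 3 in one place: 4-fluorophenyl in place of ethyl on an aromatic carbon. The two steps that bear on this change point the same way, since replacing ethyl by a group carrying a six-membered aromatic ring gave the lower numbers of compound 1 and compound 2. A step of similar size back downward is therefore expected, estimated as a 3.3-fold lower number from compound 3 to compound 4 (0.51 log units; beyond the scatter). Compound 4 is expected to give about 800 nM in this assay, with a range from 350 nM to 1800 nM.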

Compound 4, half-maximal effective concentration: 670 nM
Compound 4: middle estimate off by 1.2-fold (0.08 log units), on the high side; the range from low to high includes it.
By their numbers in this assay, from the lowest: compounds 1, 4 and 2 (each within the scatter of the next); then compound 3.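

Replacing ethyl with 4-fluorophenyl gives a 3.9-fold lower number from compound 3 to compound 4 (0.59 log units; beyond the scatter) in this assay, so a third group carrying a six-membered aromatic ring lands on the low side of ethyl. The steps of a 1.4-fold lower number from compound 2 to compound 4 (0.15 log units; within the scatter) and a 1.1-fold higher number from compound 1 to compound 4 (0.06 log units; within the scatter) stay within the scatter, so these three aromatic groups cannot be told apart at this position, whether the ring bears fluoro or isopropyl or is naphthalen-1-yl. No available data explain this result. Still open, as far as these compounds go, is whether an aromatic ring is needed here or any larger group will do, which a cyclohexyl ring or a longer chain such as hexyl would test.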